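The source may hold more compounds than are shown below. What is called first, only, known or untested is meant among the compounds shown, and "the series" means these compounds.

Three compounds share one core and differ only in a single group on an aromatic carbon. Compound 1 `Cc1cnc(N2CCC(c3coc4c(N5CCc6cc(S(C)(=O)=O)ccc65)ncnc34)CC2)nc1` gives, in a functional assay on cells for agonist activity at Glucose-dependent insulinotropic receptor (Homo sapiens), read by a luciferase reporter, with a stated time of 4 h (on this read-out higher numbers stand for an effect only at larger amounts of compound and lower numbers for an effect already at smaller amounts), 252 nM; compound 2 `CC(O)c1cnc(N2CCC(c3coc4c(N5CCc6cc(S(C)(=O)=O)ccc65)ncnc34)CC2)nc1` gives 586 nM in this assay, and compound 3 `CS(=O)(=O)c1ccc2c(c1)CCN2c1ncnc2c(C3CCN(c4ncc(Cl)cn4)CC3)coc12` gives 42 nM, the lowest of the three numbers. The steps of a 6.0-fold lower number from compound 1 to compound 3 (0.78 log units; beyond the scatter) and a 14-fold lower number from compound 2 to compound 3 (1.14 log units; beyond the scatter) lie beyond the scatter, as does a 2.3-fold higher number from compound 1 to compound 2 (0.37 log units; beyond the scatter). Compound 4 `CS(=O)(=O)c1ccc2c(c1)CCN2c1ncnc2c(C3CCN(c4ncc(F)cn4)CC3)coc12` differs from compound 3 by fluoro in place of chloro on an aromatic carbon. Among the compounds with values here, no measured step exchanges one halogen for another; the nearest guide is a 6.0-fold lower number from compound 1 to compound 3 (0.78 log units; beyond the scatter), where chloro entered at the same aromatic carbon. A small to modest upward step in this assay is therefore expected, a 2.4-fold higher number from compound 3 to compound 4 (0.38 log units; beyond the scatter). For compound 4 the estimate is 100 nM, between 40 nM and 300 nM.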

Compound 4, half-maximal effective concentration: 201 nM
For compound 4 the middle estimate is 2.0-fold (0.30 log units) below the measured one; the range from low to high includes it.
By their numbers in this assay, from the lowest: compound 3; then compounds 4 and 1 (each within the scatter of the next); then compound 2.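

The two halogens are not interchangeable at this aromatic carbon: with a 4.8-fold higher number from compound 3 to compound 4 (0.68 log units; beyond the scatter), the low number seen with chloro does not carry over to fluoro. Fluoro instead stands level with methyl, with a 1.3-fold lower number from compound 1 to compound 4 (0.10 log units; within the scatter) inside the scatter, yet it still gives a lower number than 1-hydroxyethyl, with a 2.9-fold lower number from compound 2 to compound 4 (0.46 log units; beyond the scatter). Nothing available explains the gap between the two halogens. From the compounds shown here alone, whether bromo or a nitrile at this carbon would extend the trend from fluoro to chloro, or break it, remains open.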